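The source may hold more compounds than are shown below. What is called first, only, known or untested is meant among the compounds shown, and "the series" means these compounds.

Measured so far in a functional assay for agonist activity at growth hormone secretagogue receptor type 1 (Homo sapiens), read by FLIPR; a higher number here means that more compound is needed for the effect, a lower number that less compound is needed:
- compound 1 `COc1ccc(F)c(-c2ccc(S(=O)(=O)Nc3cc(N4C[C@@H](C)N[C@@H](C)C4)ccc3OC)cc2)c1`: 0.398 nM
- compound 2 `COc1cccc(-c2ccc(S(=O)(=O)Nc3cc(N4C[C@@H](C)N[C@@H](C)C4)ccc3OC)cc2)c1`: 2 nM

Among the measured compounds shown here, compound 2 holds the higher of the two numbers; the only step between measured compounds, a 5.0-fold higher number from compound 1 to compound 2 (0.70 log units; beyond the scatter), is hydrogen in place of fluoro on an aromatic carbon and sets compound 2 apart from compound 1 by a margin that lies beyond the scatter.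

Compound 3 `COc1ccc(N2C[C@@H](C)N[C@@H](C)C2)cc1NS(=O)(=O)c1ccc(-c2ccncc2)cc1` has not been measured. Relative to compound 2 the change is pyridin-4-yl in place of 3-methoxyphenyl on an aromatic carbon.

For the measured compounds named here, no measured step touches this part of the structure; the one known step, a 5.0-fold higher number from compound 1 to compound 2 (0.70 log units; beyond the scatter), concerns a substituent on the ring that is itself replaced here, so it gives only an indication of how sensitive this assay is to changes at that end of the molecule, not of the direction. With one pair only, the expectation for compound 3 rests on compound 2 alone, and a step of roughly the size of a 3.0-fold higher number from compound 2 to compound 3 (0.48 log units; beyond the scatter) toward a higher number is estimated, with wide uncertainty either way.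

Compound 3 is therefore expected to give about 6 nM in this assay, within a range of 1.5 nM to 30 nM.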

Compound 3, half-maximal effective concentration: 316 nM
For compound 3 the middle estimate is 53-fold (1.72 log units) below the measured one; the measured number lies above the stated range.
By their numbers in this assay, from the lowest: compound 1; then compound 2; then compound 3.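

In this assay the group on an aromatic carbon, para to a large group, proves much more sensitive to exchange of the whole ring than the fluoro change alone indicated: beside the earlier 5.0-fold higher number from compound 1 to compound 2 (0.70 log units; beyond the scatter) for hydrogen in place of fluoro, pyridin-4-yl in place of 3-methoxyphenyl gives a 160-fold higher number from compound 2 to compound 3 (2.20 log units; beyond the scatter) despite the same counts of hydrogen-bond donors and acceptors in the leaving and entering groups. Measured against the fluorinated ring, pyridin-4-yl in place of 2-fluoro-5-methoxyphenyl gives a 790-fold higher number from compound 1 to compound 3 (2.90 log units; beyond the scatter) in this series, so a six-membered aromatic ring at this place does not by itself preserve the low numbers of the two methoxy-bearing compounds. Nothing available accounts for the size of these steps.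

Compound 3 loses the methoxy group and gains the ring nitrogen in a single exchange, so the share of each remains unresolved; an unsubstituted phenyl ring or a methoxy-bearing pyridine ring would separate the two. As far as these compounds go, whether fluoro on a pyridine ring would lower the number, as it does on the methoxyphenyl ring, also remains open.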